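The source may hold more compounds than are shown below. What is called first, only, known or untested is meant among the compounds shown, and "the series" means these compounds.

Three compounds share one core and differ only in the group on the aromatic nitrogen. Compound 1 `CC1(C)[C@H]2CC[C@]1(C)N(Cc1cn(-c3ccccc3C#N)nn1)C(=O)C2` gives 180 nM in a functional assay on HepG2 cells (Homo sapiens) for inhibition, read by MTT assay, with a stated time of 24 h; a higher number here means a weaker inhibitor, a lower number a stronger inhibitor. Compound 2 `CC1(C)[C@H]2CC[C@]1(C)N(Cc1cn(-c3ccccc3Cl)nn1)C(=O)C2` gives 60 nM and compound 3 `CC1(C)[C@H]2CC[C@]1(C)N(Cc1cn(-c3ccc(Br)cc3)nn1)C(=O)C2` gives 110 nM. Compound 2 has the lowest number of the three: there is a 3.0-fold lower number from compound 1 to compound 2 (0.48 log units; beyond the scatter), beyond the scatter, whereas a 1.8-fold higher number from compound 2 to compound 3 (0.26 log units; within the scatter) stays within it, so compound 2 and compound 3 cannot be ranked against each other. Compound 4 `CC1(C)[C@H]2CC[C@]1(C)N(Cc1cn(-c3cccc(Br)c3)nn1)C(=O)C2` is not yet measured and differs from compound 2 thus: 3-bromophenyl in place of 2-chlorophenyl on an aromatic nitrogen. The step that bears on this is a 1.8-fold higher number from compound 2 to compound 3 (0.26 log units; within the scatter), which stayed within the scatter, so no change beyond the scatter is expected, and a 1.4-fold higher number from compound 2 to compound 4 (0.15 log units; within the scatter) is the estimated step. Compound 4 is expected to give 85 nM, in the range 40 nM to 180 nM.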

Compound 4, half-maximal inhibitory concentration: 20 nM
Beside the measured number, compound 4's estimate is 4.3-fold (0.63 log units) above it; measured number below the stated range.
By their numbers in this assay, from the lowest: compound 4; then compounds 2, 3 and 1 (each within the scatter of the next, the first and the last beyond it).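

In this assay, for the compounds shown here, going from 4-bromophenyl to 3-bromophenyl on the aromatic nitrogen keeps the same atoms yet gives a 5.5-fold lower number from compound 3 to compound 4 (0.74 log units; beyond the scatter) and so shows that where the bromine sits on the phenyl ring matters, which the earlier compounds could not show. With a 3.0-fold lower number from compound 2 to compound 4 (0.48 log units; beyond the scatter) and a 9.0-fold lower number from compound 1 to compound 4 (0.95 log units; beyond the scatter) as well, compound 4 is the strongest inhibitor of the four. Nothing available explains this difference.

As far as these compounds go, whether 2-bromophenyl would give a similar number remains open. So does whether 3-chlorophenyl, 3-methoxyphenyl or 3-aminophenyl would keep the gain.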